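This account rests on a few compounds, and the source may have more. Where it says the series, first, only, none or still open, it means among the compounds named here.

Measured so far in a physicochemical assay for lipophilicity, read by HPLC, using the shake flask method, measured as octanol-water partition, at pH 7.4; a lower number here means a more polar compound, a higher number a more lipophilic compound:

- compound 1 `Cc1cc2ncncc2cc1Nc1ncc2c(n1)n(C1CCOCC1)c(=O)n2C`: 2.2
- compound 2 `Cc1cc2ncccc2cc1Nc1ncc2c(n1)n(C1CCN(C)CC1)c(=O)n2C`: 1.8
- compound 3 `Cc1cc2ncccc2cc1Nc1ncc2c(n1)n(C1CCNCC1)c(=O)n2C`: 0.5

Compound 3, at 0.5, has the lowest of the three numbers. Compound 2 comes next at 1.8, and compound 1 is furthest away at 2.2.

The next compound to be measured is compound 4 `Cc1cc2ncccc2cc1Nc1ncc2c(n1)n([C@H]1CCN(C3COC3)C1)c(=O)n2C`. It replaces piperidin-4-yl on an aromatic nitrogen with 1-(oxetan-3-yl)pyrrolidin-3-yl, a change counted as 1-(oxetan-3-yl)pyrrolidin-3-yl in place of piperidin-4-yl on an aromatic nitrogen.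

Among the compounds with values here, one measured step bears on this change: a number 1.30 log units lower from compound 2 to compound 3 (beyond the scatter), where hydrogen takes the place of methyl on an amine nitrogen in a ring. That step is large. In compound 4, the amine nitrogen in a ring carries oxetan-3-yl rather than hydrogen, so the change points the opposite way to that step. Within the data shown here, the match is only partial, since no measured compound holds an oxetan-3-yl group or a pyrrolidin-3-yl ring. A large rise of similar size in this assay is therefore expected, with real uncertainty.

The expected change is a number 1.40 log units higher from compound 3 to compound 4 (beyond the scatter).

The estimate for compound 4 is 1.9, with an expected range from 1.3 to 2.4.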

Compound 4, distribution coefficient: 1.5
Estimate against measurement, compound 4: 0.40 log units above, within the range that was stated.
By their numbers in this assay, from the lowest: compound 3; then compounds 4 and 2 (each within the scatter of the next); then compound 1.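

At this position on the aromatic nitrogen, this assay gives a number 1.00 log units higher from compound 3 to compound 4 (beyond the scatter) when 1-(oxetan-3-yl)pyrrolidin-3-yl takes the place of piperidin-4-yl, so a ring amine carrying oxetan-3-yl does not share the low number of the free ring amine in compound 3. Set against 1-methylpiperidin-4-yl, the same group gives a number 0.30 log units lower from compound 2 to compound 4 (within the scatter), which means that, in this assay, compound 4 cannot be told apart from the methylated piperidine, even though the ring size and the group on the ring nitrogen both differ. Nothing measured here explains why these numbers fall as they do.

As far as these compounds go, the change to compound 4 alters the ring and the group on its nitrogen in a single step, so the share of each in the rise from compound 3 remains unknown. A 1-methylpyrrolidin-3-yl group or a 1-(oxetan-3-yl)piperidin-4-yl group would change only one of these at a time against the compounds shown, and the mirror-image form of the pyrrolidine in compound 4 is also open.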